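This account rests on a few compounds, and the source may have more. Where it says the series, first, only, none or still open, it means among the compounds named here.

Measured so far:
- compound 1 `Cc1cccc(COc2ccc(-c3cc(CN4CCN(Cc5ccc(C(F)(F)F)cc5)CC4)no3)cc2)c1`: 4000 nM
- compound 2 `Cc1cc(C)cc(COc2ccc(-c3cc(CN4CCN(Cc5ccc(C(F)(F)F)cc5)CC4)no3)cc2)c1`: 1600 nM
- compound 3 `Fc1cccc(COc2ccc(-c3cc(CN4CCN(Cc5ccc(C(F)(F)F)cc5)CC4)no3)cc2)c1`: 2500 nM

Three analogues of one shared core have been run in a functional assay on MCF7 cells (Homo sapiens) for antiproliferative activity, read by sulforhodamine B assay, with a stated time of 72 h; on this read-out lower numbers stand for stronger inhibition and higher numbers for weaker inhibition. Compound 1 gives 4000 nM, compound 2 gives 1600 nM and compound 3 gives 2500 nM. Compound 3 sits second highest of the three numbers; the step of a 1.6-fold higher number from compound 2 to compound 3 (0.19 log units; within the scatter) and the step of a 1.6-fold lower number from compound 1 to compound 3 (0.20 log units; within the scatter) are both within the scatter, so no ordering among compounds 1, 2 and 3 can be claimed. Among the measured compounds shown here, the only step beyond the scatter is a 2.5-fold lower number from compound 1 to compound 2 (0.40 log units; beyond the scatter).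

Compound 4 `Fc1ccc(COc2ccc(-c3cc(CN4CCN(Cc5ccc(C(F)(F)F)cc5)CC4)no3)cc2)cc1` differs from compound 3 only by 4-fluorophenyl in place of 3-fluorophenyl on a saturated chain carbon bound to an oxygen on an aromatic ring. For the measured compounds named here, no measured pair tests a move of the fluorine around the ring; the nearest comparisons, swapping fluoro for methyl on that ring, give a 1.6-fold lower number from compound 1 to compound 3 (0.20 log units; within the scatter), within the scatter. Nothing in the series therefore supports a step beyond the scatter in this assay for compound 4, in either direction. Compound 4 is expected to give 2500 nM, spanning 1000 nM to 6000 nM, corresponding to an estimated step of no change at the digits printed from compound 3 to compound 4 (within the scatter).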

Compound 4, half-maximal inhibitory concentration: 7900 nM
Estimate against measurement, compound 4: 3.2-fold (0.50 log units) below, outside the stated range (above it).
By their numbers in this assay, from the lowest: compounds 2, 3, 1 and 4 (each within the scatter of the next, the first and the last beyond it).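

In this assay, the two fluorinated compounds have the same atoms joined differently, yet a 3.2-fold higher number from compound 3 to compound 4 (0.50 log units; beyond the scatter) is beyond the scatter, so at this place on a saturated chain carbon bound to an oxygen on an aromatic ring the read-out depends on where the fluorine sits and not only on which group is present. Among the compounds shown here, this position also covers a wider span than the earlier compounds showed, with a 4.9-fold higher number from compound 2 to compound 4 (0.69 log units; beyond the scatter) as the largest step and beyond the scatter. By contrast, a 2.0-fold higher number from compound 1 to compound 4 (0.30 log units; within the scatter) is printed as within the scatter, so compound 4 cannot be separated from compound 1 and the 4-fluorophenyl group cannot be ranked against the 3-methylphenyl group.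

Nothing available explains why the 4-fluorophenyl and 3-fluorophenyl compounds differ. Still open, going by these compounds, is whether the higher number follows any group at that place on the ring or the fluorine alone, a question that 4-methylphenyl, 4-chlorophenyl or 3,5-difluorophenyl at the same place would address.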